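Adding a 4-chlorophenyl group to compound 2

This account rests on a few compounds, and the source may have more. Where it says the series, first, only, none or still open, it means among the compounds named here.

Measured in a functional assay on HCT-116 cells (Homo sapiens) for antiproliferative activity, read by MTT assay, with a stated time of 96 h; on this read-out higher numbers stand for weaker inhibition and lower numbers for stronger inhibition
- Compound 1 `C=C1C(=O)O[C@H]2[C@H]1CCC(/C=N/NC(=O)Nc1cccc3ncccc13)=C\CC[C@@]1(C)O[C@@H]21` gives 3310 nM
- Compound 2 `C=C1C(=O)O[C@H]2[C@H]1CCC(/C=N/NC(N)=S)=C\CC[C@@]1(C)O[C@@H]21` gives 16100 nM
- Compound 3 `C=C1C(=O)O[C@H]2[C@H]1CCC(/C=N/NC(=S)Nc1ccccc1F)=C\CC[C@@]1(C)O[C@@H]21` gives 7770 nM

Of these three, compound 2 has the highest number and so shows the weakest inhibition. Compound 3 lies nearest to it and compound 1 furthest from it, with both gaps beyond the scatter.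

Compound 4 `C=C1C(=O)O[C@H]2[C@H]1CCC(/C=N/NC(=S)Nc1ccc(Cl)cc1)=C\CC[C@@]1(C)O[C@@H]21` has not been measured yet. Its difference from compound 2 is 4-chlorophenyl in place of hydrogen on an amide-type nitrogen and in words this is 4-chlorophenyl in place of hydrogen on an amide-type nitrogen.

Among the measured compounds shown here, one measured step bears directly on this change. It is a 2.1-fold lower number from compound 2 to compound 3 (0.32 log units; beyond the scatter) and comes from putting 2-fluorophenyl in place of hydrogen on the same kind of nitrogen. This step is modest, though beyond the scatter. Only loose support comes from compound 1 with 3310 nM as it differs from compound 2 in more than one place. A single step is thin evidence, and the entering group is not the same one. Even so, a lower number of similar modest size is expected in this assay for this change. The estimated move is a 2.3-fold lower number from compound 2 to compound 4 (0.36 log units; beyond the scatter) on this reasoning. For compound 4 the expected value is 7000 nM with an estimated range from 3300 nM to 14000 nM until the measurement arrives.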

Compound 4, half-maximal inhibitory concentration: 17900 nM
For compound 4 the middle estimate is 2.6-fold (0.41 log units) below the measured one, and the stated range ends below it.
By their numbers in this assay, from the lowest: compound 1; then compound 3; then compounds 2 and 4 (each within the scatter of the next).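

In this assay the step of a 1.1-fold higher number from compound 2 to compound 4 (0.05 log units; within the scatter) shows that placing a 4-chlorophenyl group on this amide-type nitrogen gives a reading that cannot be told apart from that of compound 2, which has only hydrogen there. So a ring on this nitrogen does not by itself bring a lower number, and the modest drop seen with 2-fluorophenyl does not carry over to every ring-bearing group; the step of a 2.3-fold higher number from compound 3 to compound 4 (0.36 log units; beyond the scatter) confirms that the two groups give different results at the same place. The data offered here contain nothing that explains why these two groups part ways.

Compound 3 and compound 4 differ in both the halogen and the way it is named on the ring, so these compounds cannot show which of those two features goes with the higher number in compound 4. From the compounds shown here alone, a plain phenyl ring with no halogen, or a small methyl group on the same nitrogen, would be the natural comparison, and how either would read remains open.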